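Methoxy in Place of Methyl: Compound 3 to Compound 4

A few compounds are considered here, and "the series" means these few. Any claim that something is new, unique, unknown or untested is made for them only; others in the source may bear on it.

Compound 1 `COCCC1CN(c2ccccc2)NC1=O`: 480 nM; 10300 nM; 350 nM (3 entries) in an assay on isolated protein for inhibition of Polyunsaturated fatty acid 5-lipoxygenase (Rattus norvegicus); a higher number here means a weaker inhibitor, a lower number a stronger inhibitor
Compound 2 `COCCC1C(=O)NN(c2ccccc2)C1C`: 500 nM
Compound 3 `COCCC1CN(c2ccc(C)cc2)NC1=O`: 1080 nM

Among the compounds with a single number in this assay, compound 3 stands highest; its nearest neighbour is compound 2, whose number is lower by an amount beyond the usual scatter. Compound 1 is known only through (the several entries of compound 1 in this assay, 480 nM; 10300 nM; 350 nM (3 entries)), which give no single number. Compound 4 `COCCC1CN(c2ccc(OC)cc2)NC1=O` differs from compound 3 by methoxy in place of methyl on an aromatic carbon. No comparable change has been measured in this set, so the expected step is small, in either direction, and not beyond the scatter. Compound 4 is therefore expected to give about 1000 nM in this assay, within 400 nM to 2500 nM, which corresponds to an expected step of a 1.1-fold lower number from compound 3 to compound 4 (0.03 log units; within the scatter).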

Compound 4, half-maximal inhibitory concentration in the Polyunsaturated fatty acid 5-lipoxygenase assay: 1460 nM
The estimate for compound 4 lay 1.5-fold (0.16 log units) below the measured number; low and high end bracket the measured number.
By their numbers in the Polyunsaturated fatty acid 5-lipoxygenase assay, from the lowest: compound 2; then compounds 3 and 4 (each within the scatter of the next).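

In the Polyunsaturated fatty acid 5-lipoxygenase assay, methoxy in place of methyl on an aromatic carbon, para to a large group, gave a 1.4-fold higher number from compound 3 to compound 4 (0.13 log units; within the scatter), so this position accepted the added oxygen with no change beyond the scatter. In a physicochemical assay for lipophilicity (on this read-out lower numbers stand for lower lipophilicity and higher numbers for higher lipophilicity), the same change lowered lipophilicity, with compound 3 giving 1.03 and compound 4 giving 0.45 on this read-out, so at this position the two read-outs did not move together: the measured partition coefficient of compound 3, 1.03, and of compound 4, 0.45, a number 0.58 log units lower (beyond the scatter)

From the compounds shown here alone, whether an amine, a carboxylic acid or a longer chain on this carbon would leave inhibition equally unchanged remains open. The compounds shown also leave open whether any group here can give a clearly stronger inhibitor than compound 3.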